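Replacing a benzyl by 2-chlorophenyl on the sulfonamide nitrogen

The source may report more compounds than this note shows. Statements on the series, on what has been measured and on what is new or still open speak of the compounds shown alone.

Measured compounds:
compound 1 `O=C(Nc1ccc(S(=O)(=O)NCc2ccccc2)cc1)c1ccc(Cl)cc1Cl`, "not determined" (no result reported) in a functional assay on HEK293 cells for agonist activity at probable G-protein coupled receptor 27 (Homo sapiens), read by a luciferase reporter and beta-arrestin recruitment, with a stated time of 10 min; a lower number here means a smaller maximal response, a higher number a larger maximal response
compound 2 `O=C(Nc1ccc(S(=O)(=O)Nc2ccccc2)cc1)c1ccc(Cl)cc1F`, 57%
compound 3 `O=C(Nc1ccc(S(=O)(=O)Nc2ccccc2)cc1)c1ccc(I)cc1F`, 36%

Among the measured compounds shown here, compound 1 stands without a number in this assay; compounds 2 and 3, which both carry a plain phenyl on the sulfonamide nitrogen, give the only measured values, and the one step between them, a number 21 percentage points lower from compound 2 to compound 3 (beyond the scatter), concerns the benzamide ring rather than the sulfonamide substituent. Compound 4 `O=C(Nc1ccc(S(=O)(=O)Nc2ccccc2Cl)cc1)c1ccc(Cl)cc1Cl` differs from compound 1 by 2-chlorophenyl in place of benzyl on a sulfonamide nitrogen. For the measured compounds named here, no measured step bears directly on this change, so the direction of any step in this assay is open; the two measured values mark the range in which the new compound is likely to fall. Compound 4 is therefore estimated at 48%, within 20% to 85%.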

Compound 4, largest response reached (Emax), in percent of the reference or control that the assay uses: 53%
Estimate against measurement, compound 4: 5 percentage points below, and the stated range covers the measured number.
By their numbers in this assay, from the lowest: compound 3; then compounds 4 and 2 (each within the scatter of the next).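

Among the compounds shown here, no step from compound 1 to compound 4 can be read in this assay as compound 1 has no number there. No evidence bears on this result. Going by these compounds, what replacing benzyl by 2-chlorophenyl does to the maximal response stays open.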